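Swapping the Dimethylphenyl Arm for a Hydroxyphenyl

The source may report more compounds than this note shows. Statements on the series, on what has been measured and on what is new or still open speak of the compounds shown alone.

Measured so far:
compound 1 `Cn1c(=O)c(=O)n(C2CCCC2)c2nc(N/N=C/c3ccccc3)ncc21`: 48200 nM
compound 2 `Cc1cc(C)c(/C=N/Nc2ncc3c(n2)n(C2CCCC2)c(=O)c(=O)n3C)c(C)c1`: 13900 nM
compound 3 `Cc1ccc(/C=N/Nc2ncc3c(n2)n(C2CCCC2)c(=O)c(=O)n3C)cc1C`: 39000 nM

All three share one core and differ only in the aryl group on a carbon with a double bond to nitrogen. In a functional assay on PC-3 cells (Homo sapiens) for antiproliferative activity, read by MTT assay (a lower number here means a stronger inhibitor, a higher number a weaker inhibitor), compound 3 stands second highest of the three numbers, closest to compound 1, as the step of a 1.2-fold lower number from compound 1 to compound 3 (0.09 log units; within the scatter) shows, while the step of a 2.8-fold higher number from compound 2 to compound 3 (0.45 log units; beyond the scatter) sets it apart from compound 2. Compound 4 `Cn1c(=O)c(=O)n(C2CCCC2)c2nc(N/N=C/c3cccc(O)c3)ncc21` brings a new kind of change: 3-hydroxyphenyl in place of 3,4-dimethylphenyl on a carbon with a double bond to nitrogen. Both measured steps concern methyl groups on this ring and are small to modest; none brings in a hydroxyl, so there is no direct guide. The step of a 1.1-fold lower number from compound 3 to compound 4 (0.05 log units; within the scatter) is therefore expected to stay within the scatter. Compound 4 is estimated at 35000 nM, between 12000 nM and 100000 nM.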

Compound 4, half-maximal inhibitory concentration: 36300 nM
Beside the measured number, compound 4's estimate is 1.0-fold (0.02 log units) below it; the range from low to high includes it.
By their numbers in this assay, from the lowest: compound 2; then compounds 4, 3 and 1 (each within the scatter of the next).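

In this assay the hydroxyl adds a hydrogen-bond donor that the methyl-bearing rings lack, yet this gives a 1.1-fold lower number from compound 3 to compound 4 (0.03 log units; within the scatter) and a 1.3-fold lower number from compound 1 to compound 4 (0.12 log units; within the scatter) and so leaves compound 4 level with both. Compound 2 still stands apart from compound 4, with a 2.6-fold higher number from compound 2 to compound 4 (0.42 log units; beyond the scatter) on this comparison. Still open, on these data alone, is whether an amine or a carboxylic acid in place of the hydroxyl on this ring would read any differently. Nothing available explains why the hydroxyl leaves the number within the scatter.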